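The source may hold more compounds than are shown below. What is called first, only, known or untested is meant among the compounds shown, and "the series" means these compounds.

Compound 1, `COc1ccc(-c2cc3ccccc3nc2/C=C/C(=O)c2ccc(F)cc2)cc1`, gives 6990 nM in a functional assay on NCI-H460 cells (Homo sapiens) for antiproliferative activity, read by XTT assay, with a stated time of 72 h; a lower number here means a stronger inhibitor, a higher number a weaker inhibitor.
Compound 2, `COc1ccc(-c2cc3ccccc3nc2/C=C/C(=O)c2cccs2)cc1`, gives 5440 nM in this assay.

For the measured compounds named here, compound 2 holds the lowest of the two numbers measured so far in this assay, though its nearest neighbour, compound 1, sits within the scatter of it: the step of a 1.3-fold lower number from compound 1 to compound 2 (0.11 log units; within the scatter) is too small to be read as a gain. Compound 3, `COc1ccc(-c2cc3ccccc3nc2/C=C/C(=O)c2ccc(Br)s2)cc1`, is not yet measured. It differs from compound 2 by bromo in place of hydrogen on an aromatic carbon. Going by the values given here, the only measured step, from compound 1 to compound 2, exchanged the whole aryl group on the carbonyl carbon and has no direct bearing on a bromo placed on the thiophene ring; no measured pair shows what a halogen on that ring does. The expectation for compound 3 therefore rests on compound 2 alone, and the step of a 1.2-fold lower number from compound 2 to compound 3 (0.08 log units; within the scatter) is expected to stay within the scatter, with no clear direction. Compound 3 is estimated to give 4500 nM in this assay, in a range from 1500 nM to 13000 nM.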

Compound 3, half-maximal inhibitory concentration: 5170 nM
Compound 3: middle estimate off by 1.1-fold (0.06 log units), on the low side, and the stated range covers the measured number.
By their numbers in this assay, from the lowest: compounds 3, 2 and 1 (each within the scatter of the next).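

Bromo in place of hydrogen on the aromatic carbon next to the ring sulfur, which turns thiophen-2-yl into 5-bromothiophen-2-yl, gives a 1.1-fold lower number from compound 2 to compound 3 (0.02 log units; within the scatter) in this assay, so a bromine atom at this position leaves no readable mark on the number. The wider exchange on the carbonyl carbon reads the same way, with a 1.4-fold lower number from compound 1 to compound 3 (0.13 log units; within the scatter), which means that the groups 4-fluorophenyl, thiophen-2-yl and 5-bromothiophen-2-yl cannot be told apart in this assay among these three compounds. Nothing available explains this flat result or gives a measured property of the bromo group.

From the compounds shown here alone, whether a different group on this same ring carbon, such as an amine, a carboxylic acid or a longer alkyl chain, would carry the number beyond the scatter remains open. Also open, going by these compounds, is whether any change to the shared core, rather than to the group on the carbonyl carbon, would move the number further than these exchanges have.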